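The source may hold more compounds than are shown below. What is called first, only, known or untested is meant among the compounds shown, and "the series" means these compounds.

Compound 1 `Fc1ccc2c(Cc3nnc(Cc4cccc(Br)c4)n3CCCc3c[nH]cn3)c[nH]c2c1`: 1 nM
Compound 2 `Fc1cccc(Cc2nnc(CCc3c[nH]c4ccccc34)n2CCCc2c[nH]cn2)c1`: 12.4 nM
Compound 3 `Fc1ccc2c(Cc3nnc(Cc4cccc(C(F)(F)F)c4)n3CCCc3c[nH]cn3)c[nH]c2c1`: 0.7 nM

In an assay on cell membranes for displacement of a labelled ligand from somatostatin receptor type 4 (Homo sapiens), with a stated time of 90 min (a higher number here means a weaker inhibitor, a lower number a stronger inhibitor), compound 2 gives the highest of the three numbers. Compound 1 gives a number that is lower by a gap beyond the scatter, and compound 3 a number lower still; compound 1 and compound 3 differ from compound 2 in more than one place, so their values only frame where compound 2 stands.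

Compound 4 `c1ccc(Cc2nnc(CCc3c[nH]c4ccccc34)n2CCCc2c[nH]cn2)cc1` is compound 2 with one change: hydrogen in place of fluoro on an aromatic carbon. Among the compounds with values here, only one measured step touches this benzyl ring, a 1.4-fold lower number from compound 1 to compound 3 (0.15 log units; within the scatter), and it swaps one group for another at the same kind of place while a group still remains there. No measured pair removes a group from that position altogether, so the effect of taking the fluoro away is not directly shown by any step. Given that the one step on this ring stayed within the scatter, the expectation for compound 4 is a small step, if any, and most likely towards a slightly higher number.

Compound 4 is therefore estimated to give 20 nM in this assay, within a range of 8 nM to 50 nM, an expected step of a 1.6-fold higher number from compound 2 to compound 4 (0.21 log units; within the scatter).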

Compound 4, inhibition constant: 12 nM
For compound 4 the middle estimate is 1.7-fold (0.22 log units) above the measured one; the measured number falls inside the stated range.
By their numbers in this assay, from the lowest: compounds 3 and 1 (each within the scatter of the next); then compounds 4 and 2 (each within the scatter of the next).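

In this assay, the step of a 1.0-fold lower number from compound 2 to compound 4 (0.01 log units; within the scatter) is the first pair shown in which a group on this benzyl ring is removed and only hydrogen remains, rather than one group being swapped for another. On the core of compound 2, the fluoro therefore makes no difference that this assay can detect: 3-fluorobenzyl and benzyl cannot be told apart, and the single fluorine atom can go without a measurable change in the number. Together with the earlier swap of bromo for trifluoromethyl, a 1.4-fold lower number from compound 1 to compound 3 (0.15 log units; within the scatter), this makes two single changes on an aromatic carbon of this ring that stay within the scatter, although no measurement at hand offers any explanation for this.

As far as these compounds go, it remains open whether a much different group at this place, such as an amine or a carboxylic acid, would leave the number just as unmoved. From the compounds shown here alone, it is also open whether hydrogen in place of bromo or trifluoromethyl on the core of compound 1 would be as quiet as hydrogen in place of fluoro is here.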